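Swapping the Aryl Group on a Sulfonamide Nitrogen

The source may report more compounds than this note shows. Statements on the series, on what has been measured and on what is new or still open speak of the compounds shown alone.

In a functional assay on A2780 cells (Homo sapiens) for antiproliferative activity, read by MTT assay, with a stated time of 72 h (a lower number here means a stronger inhibitor of growth, a higher number a weaker inhibitor of growth), the measured compounds give these values
Compound 1 `COc1cc(OC)c(/C=C/S(=O)(=O)Cc2cnc(OC)cn2)c(OC)c1` gives 490 nM
Compound 2 `CCOc1cnc(CS(=O)(=O)/C=C/c2c(OC)cc(OC)cc2OC)cn1` gives 540 nM
Compound 3 `COc1cc(OC)c(/C=C/S(=O)(=O)Nc2ccc(Cl)nc2)c(OC)c1` gives 2600 nM

Compound 3 at 2600 nM has the highest number of the three, beyond the scatter of both others. Compound 4 `CCOc1ccc(NS(=O)(=O)/C=C/c2c(OC)cc(OC)cc2OC)cc1` carries 4-ethoxyphenyl in place of 6-chloropyridin-3-yl on a sulfonamide nitrogen. Among the measured compounds shown here, no measured step covers this swap. The nearest is a 1.1-fold higher number from compound 1 to compound 2 (0.04 log units; within the scatter) for methyl in place of hydrogen on a saturated chain carbon bound to an oxygen on an aromatic ring, so that change alone suggests no shift. Compound 1 at 490 nM and compound 2 at 540 nM hint at lower numbers, though both differ from compound 3 in more than this group. The expected change is a 3.7-fold lower number from compound 3 to compound 4 (0.57 log units; beyond the scatter) in this assay as an uncertain estimate. For compound 4 the estimated value is 700 nM with an expected range of 200 nM to 2500 nM.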

Compound 4, concentration for 50% growth inhibition: 310 nM
The estimate for compound 4 lay 2.3-fold (0.35 log units) above the measured number; the measured number falls inside the stated range.
By their numbers in this assay, from the lowest: compounds 4, 1 and 2 (each within the scatter of the next); then compound 3.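

Among the compounds shown here, the only earlier step, methyl added to a chain on an oxygen, stayed within the scatter, so it said nothing about the sulfonamide nitrogen. In this assay, the group on that nitrogen clearly matters: 4-ethoxyphenyl in place of 6-chloropyridin-3-yl gives an 8.4-fold lower number from compound 3 to compound 4 (0.92 log units; beyond the scatter). No measurement shown here explains this step. The swap changes the ring and its substituent together, so the compounds shown cannot tell which of the two carries the step. From the compounds shown here alone, how a 4-aminophenyl or 4-carboxyphenyl group on the same nitrogen would behave also remains open.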